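This account rests on a few compounds, and the source may have more. Where it says the series, first, only, none or still open, it means among the compounds named here.

For the measured compounds named here, in an assay on MDA-MB-231 cells for displacement of a labelled ligand from C-X-C chemokine receptor type 4 (Homo sapiens), read by fluorescence and microscopy, with stated times of 10 min and 30 min (on this read-out lower numbers stand for an effect already at smaller amounts and higher numbers for an effect only at larger amounts of compound), compound 2 `Cc1cccc(S(=O)(=O)NCc2ccc(CNC(=O)c3cccnc3)cc2)c1` gives 10 nM, the lowest of the two numbers so far, and compound 1 `O=C(NCc1ccc(CNS(=O)(=O)c2ccccc2Cl)cc1)c1cccnc1` gives 100 nM. Going by the values given here, the only measured step, a 10-fold lower number from compound 1 to compound 2 (1.00 log units; beyond the scatter), concerns the aryl group on the sulfonyl sulfur, and the other end of the shared core has not been varied. Among the compounds with values here, compound 3 `COc1ccccc1C(=O)NCc1ccc(CNS(=O)(=O)c2cccc(C)c2)cc1` is the first change on that other end: 2-methoxyphenyl in place of pyridin-3-yl on a carbonyl carbon. Within the data shown here, the change sits on the carbonyl carbon whose other neighbour is the amide-type nitrogen, so the step from compound 1 to compound 2 does not bear on it, and no measured step does. With nothing to go on at this position, no step beyond the scatter is assumed, but the range is left wide and leans toward higher numbers. The step that this implies, a 2.0-fold higher number from compound 2 to compound 3 (0.30 log units; within the scatter), is expected to stay within the scatter. Compound 3 is therefore estimated at 20 nM, with a range from 5 nM to 100 nM.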

Compound 3, effective concentration (reported as EC, without a stated level of effect): 1000 nM
The estimate for compound 3 lay 50-fold (1.70 log units) below the measured number; the measured number lies above the stated range.
By their numbers in this assay, from the lowest: compound 2; then compound 1; then compound 3.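

In this assay, the carbonyl carbon whose other neighbour is the amide-type nitrogen proves to be a sensitive position: a 100-fold higher number from compound 2 to compound 3 (2.00 log units; beyond the scatter) is a larger step than a 10-fold lower number from compound 1 to compound 2 (1.00 log units; beyond the scatter) at the sulfonyl sulfur. The change removes the ring nitrogen of pyridin-3-yl and brings in the methoxy group of 2-methoxyphenyl in a single step, so the two cannot be separated here. No supporting data are available to account for the size of this step.

Going by these compounds, it remains open whether the ring nitrogen, the methoxy group or both go with the higher number. A plain phenyl, a 3-methoxyphenyl or a pyridin-4-yl on the same carbonyl carbon would help to separate these contributions, and any effect of pairing such groups with other aryl groups on the sulfonyl sulfur is also unresolved.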